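The source may hold more compounds than are shown below. What is called first, only, known or untested is meant among the compounds shown, and "the series" means these compounds.

Measured compounds:
compound 1, `O=C(CN1CCC(c2cccc[n+]2[O-])CC1)Nc1cccc(Cl)c1`: 62 nM
compound 2, `CSc1cccc(NC(=O)CN2CCC(c3cccc[n+]3[O-])CC2)c1`: 100 nM
compound 3, `O=C(CN1CCC(c2cccc[n+]2[O-])CC1)Nc1ccc(F)cc1F`: 103 nM

All three share one core and differ only in the aryl group on the amide-type nitrogen, and all three were tested in a functional assay on HEK293 cells for agonist activity at D(4) dopamine receptor (Homo sapiens), read by FLIPR; a higher number here means that more compound is needed for the effect, a lower number that less compound is needed. Compound 2 stands second highest of the three numbers; the steps of a 1.0-fold higher number from compound 2 to compound 3 (0.01 log units; within the scatter) and a 1.6-fold higher number from compound 1 to compound 2 (0.21 log units; within the scatter) both lie within the scatter, as does a 1.7-fold higher number from compound 1 to compound 3 (0.22 log units; within the scatter). Going by the values given here, no measured compound is therefore separated from another beyond the scatter.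

Compound 4, `O=C(CN1CCC(c2cccc[n+]2[O-])CC1)Nc1cccc(C(F)(F)F)c1`, has not yet been measured. Compared with compound 2 the change is trifluoromethyl in place of methylsulfanyl on an aromatic carbon. Among the compounds with values here, only the step of a 1.6-fold higher number from compound 1 to compound 2 (0.21 log units; within the scatter) touches the same position, and it is within the scatter; no measured step involves trifluoromethyl. Every change of the aryl group seen so far has stayed within the scatter, so no step beyond the scatter is expected here either, in either direction. Compound 4 is expected to give 80 nM, within a range from 35 nM to 200 nM. For compound 4 this estimate means a 1.3-fold lower number from compound 2 to compound 4 (0.10 log units; within the scatter).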

Compound 4, half-maximal effective concentration: 76 nM
Compound 4: the middle estimate sits 1.1-fold (0.02 log units) above what was measured, and the stated range covers the measured number.
By their numbers in this assay, from the lowest: compounds 1, 4, 2 and 3 (each within the scatter of the next).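

Putting trifluoromethyl in place of methylsulfanyl gives a 1.3-fold lower number from compound 2 to compound 4 (0.12 log units; within the scatter) in this assay and putting it in place of chloro gives a 1.2-fold higher number from compound 1 to compound 4 (0.09 log units; within the scatter) so three different groups on this aromatic carbon now lie within the scatter of one another. The change from compound 2 removes the sulfur and the single hydrogen-bond acceptor of methylsulfanyl and brings four heavy atoms in place of two, yet no step beyond the scatter appears. Nothing available on these compounds bears on why this change leaves the number within the scatter.

As far as these compounds go, whether an amine, a carboxylic acid or a longer chain on this carbon would also stay within the scatter remains open. Also open is what a change in the shared core would do, as all the compounds shown carry it unchanged.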